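A Sulfonyl Swap: Methylamino for Methyl in Compound 3

The compounds below may be only part of what the source reports. "The series", "measured", "known", "first", "only" and "open" are said of these compounds alone.

In a functional assay on cells for antagonist activity at C-C chemokine receptor type 1 (Homo sapiens), read by FLIPR and calcium flux (on this read-out higher numbers stand for weaker inhibition and lower numbers for stronger inhibition), compound 2 `Cc1c(C(=O)NCc2ccc(S(C)(=O)=O)cc2)cnn1-c1ccc(Cl)cc1` gives 1700 nM. Compound 1 `Nc1c(C(=O)NCc2cccc(C(F)(F)F)c2)cnn1-c1ccc(Cl)cc1` reaches only a limit of the assay, > 3000 nM (the limit of > 3000 nM in this assay, at which 1 of the 2 values shown sits). For the measured compounds named here, because compound 1 sits at the limit of > 3000 nM in this assay, at which 1 of the 2 values shown sits, compound 2 holds the one numerical value shown, and the two compounds cannot be placed in any order beyond what that limit states. Compound 3 `CNS(=O)(=O)c1ccc(CNC(=O)c2cnn(-c3ccc(Cl)cc3)c2C)cc1` has not yet been measured. It differs from compound 2 in a single place: methylamino in place of methyl on a sulfonyl sulfur. Going by the values given here, no pair of measured compounds shows a change of this kind, so there is no directly comparable step to draw on, and the new group brings one hydrogen-bond donor where none stood before. The expected step from compound 2 to compound 3 is a 1.1-fold lower number from compound 2 to compound 3 (0.05 log units; within the scatter), no larger than the usual scatter of repeated measurements. Compound 3 is therefore estimated at 1500 nM, within a range from 500 nM to 4500 nM.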

Compound 3, half-maximal inhibitory concentration: 420 nM
For compound 3 the middle estimate is 3.6-fold (0.55 log units) above the measured one; measured number below the stated range.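

In this assay the sulfonyl sulfur turns out to be a place where one small change moves the number: methylamino in place of methyl gives a 4.0-fold lower number from compound 2 to compound 3 (0.61 log units; beyond the scatter) and so reaches past the noise of the measurement. The earlier compounds shown here could not show this, since no two of them differed in one place only. Nothing measured here tells why the number falls with this change.

Still open, going by these compounds, is which part of the methylamino group matters, the nitrogen with its hydrogen or the methyl on it. A plain amino group or a dimethylamino group on the same sulfur would help to separate these, and a longer chain such as ethylamino would show whether the sulfur tolerates more bulk of carbon.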